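This account rests on a few compounds, and the source may have more. Where it says the series, first, only, none or still open, it means among the compounds named here.

Measured in a functional assay on CHO/Galpha16 cells for antagonist activity at prostaglandin E2 receptor EP4 subtype (Homo sapiens), read by calcium flux, with a stated time of 15 min; on this read-out higher numbers stand for weaker inhibition and lower numbers for stronger inhibition:
compound 1 `C[C@H](NC(=O)c1c(Cc2ccc(C(C)(C)C)cc2)sc2c1CCOC2)c1ccc(C(=O)O)cc1` — compound 1 gives 9.5 nM
compound 2 `C[C@H](NC(=O)c1c(C#Cc2ccc(F)cc2)sc2c1CCOC2)c1ccc(C(=O)O)cc1` — compound 2 gives 15.8 nM
compound 3 `C[C@H](NC(=O)c1c(NC(=O)c2ccc(F)cc2)sc2c1CCOC2)c1ccc(C(=O)O)cc1` — compound 3 gives > 1000 nM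

The value of compound 3 is a limit of this assay and not a number; compound 3 is the one that sits at the limit of > 1000 nM in this assay, at which 1 of the 3 values shown sits. Among the three, compound 1 and compound 2 lie within the scatter of each other a 1.7-fold higher number from compound 1 to compound 2 (0.22 log units; within the scatter), whereas the ((4-fluorophenyl)carbonyl)amino group of compound 3 stands far off: an at least 100-fold higher number from compound 1 to compound 3 (2.02 log units; beyond the scatter) and an at least 63-fold higher number from compound 2 to compound 3 (1.80 log units; beyond the scatter).

Compound 4 `C[C@H](NC(=O)c1c(C#Cc2ccc(=O)[nH]c2)sc2c1CCOC2)c1ccc(C(=O)O)cc1` differs from compound 3 by a group of 9 heavy atoms (7 carbon, 1 nitrogen, 1 oxygen; one six-membered aromatic ring with 1 hetero atom) in place of a group of 10 heavy atoms (7 carbon, 1 nitrogen, 1 oxygen, 1 fluorine; one six-membered aromatic ring of carbon only), on an aromatic carbon. Going by the values given here, the change removes the ((4-fluorophenyl)carbonyl)amino group and brings back a triple-bond link to an aromatic ring on the same carbon of the core, so the steps that bear on it are the two large ones just named, now run in the opposite direction. The closest comparison is compound 2, whose step an at least 63-fold higher number from compound 2 to compound 3 (1.80 log units; beyond the scatter) was large, and the new ring is not that of compound 2, so some of that distance may not be recovered. Still, a large step down in this assay is expected, an at least 28-fold lower number from compound 3 to compound 4 (1.45 log units; beyond the scatter). For compound 4 the estimate is 35 nM, with a range from 6 nM to 300 nM.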

Compound 4, half-maximal inhibitory concentration: 642 nM
Estimate against measurement, compound 4: 18-fold (1.26 log units) below, outside the stated range (above it).
By their numbers in this assay, from the lowest: compounds 1 and 2 (each within the scatter of the next); then compound 4. At a limit, above all of these: compound 3.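

On a triple-bonded carbon, a six-membered aromatic ring with 1 hetero atom in place of the 4-fluorophenyl ring of compound 2 costs much in this assay, a 41-fold higher number from compound 2 to compound 4 (1.61 log units; beyond the scatter), so the triple-bond link does not by itself hold the number of compound 2 and the ring at its end matters, which compounds 1, 2 and 3 could not show. The same distance appears against the 4-(tert-butyl)benzyl group, a 68-fold higher number from compound 1 to compound 4 (1.83 log units; beyond the scatter), so compound 4 stands apart from both compounds that lie within the scatter of each other. Compound 3 carries a limit of the assay and not a number, which leaves an at least 1.5-fold lower number from compound 3 to compound 4 (0.19 log units; that floor lies within the scatter) as a floor only, and the gap between these two compounds stays unresolved: the limit of > 1000 nM in this assay, at which 1 of the 4 values shown sits.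

The compounds shown do not separate the ring nitrogen and its hydrogen from the ring carbonyl of the entering group, so which part of it goes with the step stays open. From the compounds shown here alone, whether an amine, a methoxy group or a nitrile in place of the fluorine on the carbon-only ring keeps the number of compound 2 is also open.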